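Aryl amide variation on the shared chain, compounds 2 to 3

The compounds below may be only part of what the source reports. "The series", "measured", "known", "first", "only" and "open" are said of these compounds alone.

Measured in a functional assay on HCT-116 cells (Homo sapiens) for inhibition, read by colorimetric assay, with a stated time of 3 days; a lower number here means a stronger inhibitor, a higher number a weaker inhibitor:
compound 1 `O=C(CCCCCCNC(=O)C(O)(O)C(F)(F)F)Nc1nccs1`: 10800 nM
compound 2 `COc1ccccc1NC(=O)CCCCCCNC(=O)C(O)(O)C(F)(F)F`: 10100 nM

Going by the values given here, compound 2 gives the lowest of the two numbers so far, but compound 1 sits within the scatter of it, so the two are not distinguished and neither can be called the more potent. The only difference between them is the group on the amide-type nitrogen, and the step of a 1.1-fold lower number from compound 1 to compound 2 (0.03 log units; within the scatter) shows that this exchange moved nothing beyond the scatter.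

Compound 3 `O=C(CCCCCCNC(=O)C(O)(O)C(F)(F)F)Nc1ccc(Cl)cc1` is not yet measured. Against compound 2 it differs in 4-chlorophenyl in place of 2-methoxyphenyl on an amide-type nitrogen; the same difference, cut one bond further out, reads (2-methoxyphenyl)amino to (4-chlorophenyl)amino. Among the compounds with values here, the single measured step that bears on this, a 1.1-fold lower number from compound 1 to compound 2 (0.03 log units; within the scatter), changed the group at the very same place and stayed within the scatter, so there is no basis for expecting a step beyond the scatter in this assay in either direction; the wider series gives no other guide.

Compound 3 is therefore expected near 10000 nM in this assay, within 4000 nM to 25000 nM, which means an expected step of a 1.0-fold lower number from compound 2 to compound 3 (0.00 log units; within the scatter).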

Compound 3, half-maximal inhibitory concentration: 4230 nM
Compound 3: middle estimate off by 2.4-fold (0.37 log units), on the high side; the range from low to high includes it.
By their numbers in this assay, from the lowest: compound 3; then compounds 2 and 1 (each within the scatter of the next).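

The group on the amide-type nitrogen can move the number in this assay: the exchange between 1,3-thiazol-2-yl and 2-methoxyphenyl stayed within the scatter, whereas 4-chlorophenyl gives a 2.4-fold lower number from compound 2 to compound 3 (0.38 log units; beyond the scatter) and a 2.6-fold lower number from compound 1 to compound 3 (0.41 log units; beyond the scatter), so this position is not silent, though both steps are small. The comparison with compound 2 changes the substituent and its place on the phenyl ring together, with 2-methoxyphenyl carrying one hydrogen-bond acceptor and 4-chlorophenyl none, so this single pair cannot assign the shift to any one of these differences. No measurement in hand accounts for the shift.

Still open, going by these compounds, is whether chlorine itself matters or only the place of the substituent, a question that plain phenyl, 4-methoxyphenyl and 2-chlorophenyl on the same nitrogen would separate. Also open, on these data alone, is whether a longer chain, or a carboxylic acid or an amine on the phenyl ring, would carry the number further than the 4-chlorophenyl group does.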